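This account rests on a few compounds, and the source may have more. Where it says the series, first, only, none or still open, it means among the compounds named here.

Of the compounds shown here, three share one core and have been measured in a functional assay on HEK293 cells for agonist activity at G-protein coupled receptor 39 (Homo sapiens), read by scintillation proximity assay and inositol phosphate accumulation, with a stated time of 75 min, in the presence of a further agent that is not named here; a lower number here means that less compound is needed, a higher number that more compound is needed for the effect. Compound 1 `Cc1nn(-c2ncnc3nc[nH]c23)c2c1C(C(=O)Nc1ccccc1)CC(=O)N2` gives 10 nM. Compound 2 `Cc1nn(-c2ncnc3nc[nH]c23)c2c1C(C(=O)NCc1ccc(F)cc1)CC(=O)N2` gives 4 nM, the lowest of the three numbers. Compound 3 `Cc1noc(C)c1COC1CC(=O)Nc2c1c(C)nn2-c1ncnc2nc[nH]c12` gives 5 nM. Compound 3 stands nearest to compound 2, and the gap between the two is within the scatter, so no order between them can be claimed; compound 1 is furthest from compound 2, beyond the scatter.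

The step from compound 2 to compound 4 `Cc1nn(-c2ncnc3nc[nH]c23)c2c1C(C(=O)N(C)c1nccs1)CC(=O)N2` is the change (methyl(1,3-thiazol-2-yl)amino in place of (4-fluorobenzyl)amino on a carbonyl carbon). Of the measured steps, only a 2.5-fold lower number from compound 1 to compound 2 (0.40 log units; beyond the scatter) touches the same carbonyl carbon; it was a modest one. The other step, a 2.0-fold lower number from compound 1 to compound 3 (0.30 log units; within the scatter), alters a different part of the molecule and stays within the scatter, so it says little about compound 4. Compound 4 removes the 4-fluorobenzyl that distinguished compound 2 from compound 1 and places an aromatic ring directly on the nitrogen, as in compound 1, while also taking away the hydrogen-bond donor. A step of about the size of a 2.5-fold lower number from compound 1 to compound 2 (0.40 log units; beyond the scatter), but in the opposite direction, is therefore expected, giving a 2.5-fold higher number from compound 2 to compound 4 (0.40 log units; beyond the scatter). Compound 4 is estimated at 10 nM, with a range from 3 nM to 40 nM.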

Compound 4, half-maximal effective concentration: 18 nM
Compound 4: middle estimate off by 1.8-fold (0.26 log units), on the low side, within the range that was stated.
By their numbers in this assay, from the lowest: compounds 2, 3, 1 and 4 (each within the scatter of the next, the first and the last beyond it).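

In this assay, putting methyl(1,3-thiazol-2-yl)amino on the carbonyl carbon gives a 4.5-fold higher number from compound 2 to compound 4 (0.65 log units; beyond the scatter), and replacing the (3,5-dimethyl-1,2-oxazol-4-yl)methoxy on the saturated ring carbon with methyl(1,3-thiazol-2-yl)carbamoyl gives a 3.6-fold higher number from compound 3 to compound 4 (0.56 log units; beyond the scatter), so compound 4 separates from both of the two compounds with the lowest numbers. Against the anilino group the change gives a 1.8-fold higher number from compound 1 to compound 4 (0.26 log units; within the scatter), so a five-membered aromatic ring with 2 hetero atoms and no hydrogen-bond donor in this group cannot be told apart from the anilino group with its six-membered carbon ring and its donor. Nothing shown here gives a measured reason for these differences.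

From the compounds shown here alone, the methyl and the thiazole ring enter together in compound 4, so their separate contributions stay open, and (1,3-thiazol-2-yl)amino without the methyl would be the direct comparison with the anilino group. Also open, going by these compounds, is how a simple dimethylamino, or the hydroxyl of a carboxylic acid, would read on the same carbonyl carbon, with no aromatic ring in the group at all.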